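Hydroxamic acid chain length on two heteroaryl cores

The source may hold more compounds than are shown below. What is called first, only, known or untested is meant among the compounds shown, and "the series" means these compounds.

Compound 1 `Nc1nc2cc(-c3nn(CCCC(=O)NO)c4ncnc(N)c34)ccc2o1` in a functional assay on CNE-2 cells (Homo sapiens) for inhibition, read by MTT assay, with a stated time of 72 h (a higher number here means a weaker inhibitor, a lower number a stronger inhibitor), gives > 50000 nM, which is a limit of the assay.
Compound 2 `Nc1nc2cc(-c3nn(CCC(=O)NO)c4ncnc(N)c34)ccc2o1` in this assay gives > 150000 nM, a limit of the assay.
Compound 3 `Nc1ncnc2c1c(-c1cnc3[nH]ccc3c1)nn2CCC(=O)NO` in this assay gives > 150000 nM, a limit of the assay.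

Compounds 1 and 2 share one core; compound 3 carries another, and the difference between the two cores is not broken down here. From compound 2 to compound 1 the change is (hydroxycarbamoyl)methyl in place of hydroxycarbamoyl on a saturated chain carbon, two bonds along the chain from an aromatic nitrogen. The step that the two limits leave unreadable from compound 2 to compound 1 stays unreadable because the limit of > 50000 nM in this assay, at which 1 of the 3 values shown sits, and the limit of > 150000 nM in this assay, at which 2 of the 3 values shown sit, bound both values.

Compound 4 `Nc1ncnc2c1c(-c1cnc3[nH]ccc3c1)nn2CCCC(=O)NO`, not yet measured, differs from compound 3 by (hydroxycarbamoyl)methyl in place of hydroxycarbamoyl on a saturated chain carbon, two bonds along the chain from an aromatic nitrogen, the same change. The step from compound 3 to compound 4 is expected to be an at least 1.5-fold lower number from compound 3 to compound 4 (0.17 log units; that floor lies within the scatter), resting on the fact that a step that the two limits leave unreadable from compound 2 to compound 1 shows no readable size and compound 3 gives only a limit. Compound 4 is therefore expected to give about 100000 nM, with a range from 30000 nM to 300000 nM.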

Compound 4, half-maximal inhibitory concentration: > 150000 nM
Compound 4: no number, only a limit (the forecaster's own chance of this, stated with the estimate: 85%); at least 1.5-fold (0.17 log units) between middle value and limit.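

No new step can be read: compound 3 and compound 4 both give only a limit and not a number, so the size of the change between them cannot be read: the limit of > 150000 nM in this assay, at which 3 of the 4 values shown sit.

The compounds shown leave open whether the longer chain changes inhibition in this assay on either core.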